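The source may report more compounds than this note shows. Statements on the series, on what has been measured and on what is new or still open speak of the compounds shown alone.

In a functional assay on HeLa cells (Homo sapiens) for cytotoxicity, read by sulforhodamine B assay (a higher number here means a weaker inhibitor, a lower number a stronger inhibitor), three compounds built on one shared core have been measured. Compound 1 (`Cc1ccccc1S(=O)(=O)NC(C)C1=CC(=O)c2c(O)ccc(O)c2C1=O`) gives 4490 nM as its half-maximal inhibitory concentration, compound 2 (`COc1ccc(S(=O)(=O)NC(C)C2=CC(=O)c3c(O)ccc(O)c3C2=O)cc1`) gives 3760 nM on the same read-out, and compound 3 (`CC(NS(=O)(=O)c1ccc(Br)cc1)C1=CC(=O)c2c(O)ccc(O)c2C1=O`) gives 5210 nM on it too. Compound 3 cannot be separated from the other two: the data show a 1.2-fold higher number from compound 1 to compound 3 (0.06 log units; within the scatter) together with a 1.4-fold higher number from compound 2 to compound 3 (0.14 log units; within the scatter) here.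

Compound 4 (`CC(NS(=O)(=O)c1ccccc1Br)C1=CC(=O)c2c(O)ccc(O)c2C1=O`) has the same atoms as compound 3, joined differently, as 2-bromophenyl in place of 4-bromophenyl on a sulfonyl sulfur shows: 2-bromophenyl in place of 4-bromophenyl on a sulfonyl sulfur. Among the compounds with values here, no measured pair makes this exact change, so the evidence is indirect. The closest comparison is compound 1, which carries 2-methylphenyl on the sulfonyl sulfur. Exchanging that group gave a 1.2-fold lower number from compound 1 to compound 2 (0.08 log units; within the scatter) in one case and a 1.2-fold higher number from compound 1 to compound 3 (0.06 log units; within the scatter) in the other. All three measured steps stay within the scatter, so no step beyond the scatter is expected in this assay for this change either. The expected move is a 1.2-fold lower number from compound 3 to compound 4 (0.06 log units; within the scatter) and no more, and these data do not settle its direction. For compound 4 the estimate is 4500 nM with an expected range from 2500 nM up to 8000 nM in repeat measurements.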

Compound 4, half-maximal inhibitory concentration: 6200 nM
For compound 4 the middle estimate is 1.4-fold (0.14 log units) below the measured one, within the range that was stated.
By their numbers in this assay, from the lowest: compounds 2, 1, 3 and 4 (each within the scatter of the next).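

Placing the bromo group differently on the ring makes no readable difference in this assay: 2-bromophenyl in place of 4-bromophenyl on a sulfonyl sulfur gives a 1.2-fold higher number from compound 3 to compound 4 (0.08 log units; within the scatter) and so adds a change of attachment point to the earlier changes of substituent, which also stayed within the scatter. The new compound also allows two further comparisons, with a bromo group taking over from the methyl group giving a 1.4-fold higher number from compound 1 to compound 4 (0.14 log units; within the scatter) and 2-bromophenyl in place of 4-methoxyphenyl giving a 1.6-fold higher number from compound 2 to compound 4 (0.22 log units; within the scatter), so all four aryl sulfonamides remain indistinguishable in this cell test. No measurement here explains this flat result or links it to any property of the groups.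

As far as these compounds go, all four compounds carry a benzene ring with one small substituent on the sulfonyl sulfur, so it remains open whether an amine or a carboxylic acid on that ring would move the number beyond the scatter. A longer carbon chain in place of the aromatic ring is likewise untested among the compounds shown, and so the limits of this tolerance remain unknown.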